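The source may hold more compounds than are shown below. What is called first, only, known or untested is meant among the compounds shown, and "the series" means these compounds.

Measured in a physicochemical assay for solubility, read by LC-MS, with a stated time of 16 h, at pH 7; on this read-out lower numbers stand for lower solubility and higher numbers for higher solubility:
- compound 1 `CCCC[S+]([O-])c1sc2nc(-c3nccs3)cc(-c3ccc(CO)cc3)c2c1N`: 12.5 ug/mL
- compound 2 `CCCC[S+]([O-])c1sc2nc(-c3nccs3)cc(-c3ccc(CNC(=O)NCC)cc3)c2c1N`: 8.17 ug/mL

Only these two numbers are available so far, and compound 2, at 8.17 ug/mL, cannot be told apart from compound 1, at 12.5 ug/mL. The next structure is compound 3 `CCCC[S+]([O-])c1sc2nc(-c3nccs3)cc(-c3ccc(CNC(C)=O)cc3)c2c1N`, which has methyl in place of ethylamino on a carbonyl carbon. This turns the (ethylcarbamoyl)amino group into acetamido. Among the compounds with values here, only one measured step bears on this change: a 1.5-fold lower number from compound 1 to compound 2 (0.18 log units; within the scatter). That step put (ethylcarbamoyl)amino in place of hydroxy on the same saturated chain carbon. With so little evidence, and with that one step so small, no shift beyond the scatter is expected in this assay, in either direction. The estimated step is a 1.2-fold higher number from compound 2 to compound 3 (0.09 log units; within the scatter). For compound 3 the estimate is 10 ug/mL, with an expected range from 4 ug/mL to 25 ug/mL.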

Compound 3, solubility: 2.16 ug/mL
Compound 3: the middle estimate sits 4.6-fold (0.67 log units) above what was measured, outside the stated range (below it).
By their numbers in this assay, from the lowest: compound 3; then compounds 2 and 1 (each within the scatter of the next).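

In this assay the group on this carbonyl carbon proves to matter: methyl in place of ethylamino gives a 3.8-fold lower number from compound 2 to compound 3 (0.58 log units; beyond the scatter) and so a change that the earlier pair, which stayed within the scatter, did not show. Acetamido in place of hydroxy on the saturated chain carbon gives a 5.8-fold lower number from compound 1 to compound 3 (0.76 log units; beyond the scatter) and so shows that swapping out hydroxy here can move the number beyond the scatter, although (ethylcarbamoyl)amino did not. No measurement shown here explains why these two groups differ.

The compounds shown leave open whether a propyl chain or a morpholine ring on this carbonyl carbon would read like compound 2 or like compound 3. They also leave open what a free amine would give in place of hydroxy on the saturated chain carbon.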